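Oxime ether series: difluorophenyl ether, compound 3 expected

This account rests on a few compounds, and the source may have more. Where it says the series, first, only, none or still open, it means among the compounds named here.

Compound 2 `Cc1cccc(Oc2c(/C=N/OCc3snnc3C)c(C)nn2C)c1` sits at the limit of a functional assay on Huh-7 cells (Homo sapiens) for inhibition, read by MTT assay, with a stated time of 48 h (on this read-out higher numbers stand for weaker inhibition and lower numbers for stronger inhibition), reading > 50000 nM and giving no number. Compound 1 `Cc1nnsc1CO/N=C/c1c(C)nn(C)c1Oc1ccc(Br)cc1` gives 11800 nM in this assay. For the measured compounds named here, the step of an at least 4.2-fold higher number from compound 1 to compound 2 (0.62 log units; beyond the scatter) is the only measured change on this oxygen-linked ring, and it ended at the limit of > 50000 nM in this assay, at which 1 of the 2 values shown sits. Compound 3 `Cc1nnsc1CO/N=C/c1c(C)nn(C)c1Oc1cccc(F)c1F` carries 2,3-difluorophenyl in place of 3-methylphenyl on an oxygen on an aromatic ring. Going by the values given here, no measured step covers a fluorinated ring, so only a loose expectation is possible. A modest move toward lower numbers is expected for compound 3 an at least 1.4-fold lower number from compound 2 to compound 3 (0.15 log units; that floor lies within the scatter), though this assay may again report only a limit. Compound 3 is estimated at 35000 nM, between 8000 nM and 50000 nM.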

Compound 3, half-maximal inhibitory concentration: 10200 nM
Beside the measured number, compound 3's estimate is 3.4-fold (0.54 log units) above it, within the range that was stated.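

In this assay, a second halogen-bearing ring at this position, on an oxygen on an aromatic ring, gives a measured number: a 1.2-fold lower number from compound 1 to compound 3 (0.06 log units; within the scatter). The measured number therefore does not depend on 4-bromophenyl alone, and replacing 3-methylphenyl with 2,3-difluorophenyl gives an at least 4.9-fold lower number from compound 2 to compound 3 (0.69 log units; beyond the scatter). Compound 2 remains a limit of the assay, not a number: the limit of > 50000 nM in this assay, at which 1 of the 3 values shown sits.

On these data alone, whether a ring carrying an amine or a carboxylic acid would keep this level remains open. The compounds shown also leave the shared core and the oxime ether unvaried.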